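A dihydroxyphenyl analogue of two measured esters

A few compounds are considered here, and "the series" means these few. Any claim that something is new, unique, unknown or untested is made for them only; others in the source may bear on it.

compound 1 `COc1ccc(/C=C\C(=O)O[C@@H](C)[C@@H]2CC[C@H]([C@H](O)[C@H]3CC=CC(=O)O3)O2)cc1`: > 10000 nM (a limit)
compound 2 `COc1ccc(/C=C/C(=O)O[C@@H](C)[C@@H]2CC[C@H]([C@H](O)[C@H]3CC=CC(=O)O3)O2)cc1`: 5700 nM

In a functional assay on HEp-2 cells (Homo sapiens) for inhibition, read by sulforhodamine B assay, with a stated time of 72 h (on this read-out lower numbers stand for stronger inhibition and higher numbers for weaker inhibition), compound 1 gives only a limit, > 10000 nM. Within the data shown here, compound 2 gives 5700 nM, the only number among the two values shown. Compound 3 `C[C@H](OC(=O)/C=C/c1ccc(O)c(O)c1)[C@@H]1CC[C@H]([C@H](O)[C@H]2CC=CC(=O)O2)O1` differs from compound 2 by 3,4-dihydroxyphenyl in place of 4-methoxyphenyl on a double-bonded chain carbon bound to a double-bonded chain carbon. Among the measured compounds shown here, the single measured step, an at least 1.7-fold lower number from compound 1 to compound 2 (0.24 log units; that floor lies within the scatter), concerns configuration alone and says nothing about exchanging the aryl group, so no measured step bears on this change. Compound 3 is therefore expected to show no step beyond the scatter, a 1.1-fold lower number from compound 2 to compound 3 (0.06 log units; within the scatter). For compound 3 the estimate is 5000 nM, between 1500 nM and 15000 nM.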

Compound 3, half-maximal inhibitory concentration: 9400 nM
For compound 3 the middle estimate is 1.9-fold (0.27 log units) below the measured one; low and high end bracket the measured number.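

Among these compounds, the exchange of 4-methoxyphenyl for 3,4-dihydroxyphenyl on a double-bonded chain carbon bound to a double-bonded chain carbon gives a 1.6-fold higher number from compound 2 to compound 3 (0.22 log units; within the scatter) in this assay and so provides the first measured step that concerns the aryl group rather than configuration. On this one pair, replacing the 4-methoxyphenyl with 3,4-dihydroxyphenyl leaves the read-out within the scatter. Nothing available accounts for this outcome or ties it to either group. As far as these compounds go, whether an amine or a carboxylic acid on the aryl ring would move the number beyond the scatter stays open. So does the outcome with a single hydroxyl group on that ring.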